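From pyridin-2-yl to 4-cyclopropyl-1H-pyrazol-1-yl on an aromatic carbon

The compounds below may be only part of what the source reports. "The series", "measured", "known", "first", "only" and "open" are said of these compounds alone.

In a physicochemical assay for lipophilicity, at pH 7.4 (on this read-out lower numbers stand for lower lipophilicity and higher numbers for higher lipophilicity), compound 1 (`CCNC(=O)C1CCN(c2cncnc2-c2ccccc2)CC1`) gives 1.8 and compound 2 (`CCN(C)C(=O)C1CCN(c2cncnc2-c2ccccc2)CC1`) gives 2.1. Compound 3 (`CN(C)C(=O)C1CCN(c2cnccc2-c2ccccn2)CC1`) gives 1.2, the lowest of the three numbers and clear of the scatter from both others. Compound 4 (`CN(C)C(=O)C1CCN(c2cnccc2-n2cc(C3CC3)cn2)CC1`) has not yet been measured. It differs from compound 3 by 4-cyclopropyl-1H-pyrazol-1-yl in place of pyridin-2-yl on an aromatic carbon. For the measured compounds named here, the only measured step is a number 0.30 log units higher from compound 1 to compound 2 (within the scatter), for methyl in place of hydrogen on an amide-type nitrogen. That step sits on a nitrogen rather than an aromatic carbon and stays within the scatter, so it offers little guidance here. The expectation therefore rests on the structural change alone, a larger group entering on compound 3 at 1.2. A rise beyond the scatter is expected, an estimated a number 0.90 log units higher from compound 3 to compound 4 (beyond the scatter). For compound 4 the estimated value is 2.1, with an expected range from 1.6 to 2.7.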

Compound 4, distribution coefficient: 2.1
Compound 4: middle estimate and measured number agree at the digits printed; measured number inside the range.
By their numbers in this assay, from the lowest: compound 3; then compounds 1, 2 and 4 (each within the scatter of the next).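

In this assay this position responds clearly to the change: replacing pyridin-2-yl with 4-cyclopropyl-1H-pyrazol-1-yl gives a number 0.90 log units higher from compound 3 to compound 4 (beyond the scatter) and so the series has its first single-place step that clears the scatter. The earlier step, on an amide-type nitrogen, stayed within it, so only now is there a measured shift at a site on the aromatic carbon opposite the ring nitrogen. The entering group brings a five-membered aromatic ring and a three-membered carbon ring together, and no evidence is available to explain the size of this step.

The compounds shown do not separate the contribution of the five-membered aromatic ring from that of the cyclopropyl. A plain 1H-pyrazol-1-yl or a 4-methyl-1H-pyrazol-1-yl at this position would divide the step between them.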